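A few compounds are considered here, and "the series" means these few. Any claim that something is new, unique, unknown or untested is made for them only; others in the source may bear on it.

The measured compounds, with their results in a functional assay on MCF7 cells (Homo sapiens) for antiproliferative activity, read by MTT assay, with a stated time of 24 h; on this read-out higher numbers stand for weaker inhibition and lower numbers for stronger inhibition:

compound 1, `COc1cc(/C=C/C(=O)NNC(=O)c2ccccc2)ccc1O`: 5220 nM
compound 2, `O=C(/C=C/c1ccc(O)c(O)c1)NNC(=O)c1ccccc1`: 4750 nM
compound 3, `COc1ccc(C(=O)NNC(=O)/C=C/c2cc(OC)c(O)c(OC)c2)cc1`: 7170 nM

Compound 2 is made from compound 1 by one change, (hydrogen in place of methyl on an oxygen on an aromatic ring). That change gave a 1.1-fold lower number from compound 1 to compound 2 (0.04 log units; within the scatter), so the two values cannot be told apart on this read-out. Compound 3 has a different core; how the two cores differ is not broken down here. Its gaps to compound 1 and to compound 2 are both within the scatter, so no order among the three can be claimed.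

Compound 4, `COc1cc(/C=C/C(=O)NNC(=O)c2ccc(O)cc2)cc(OC)c1O`, has not yet been measured in this assay. It is made from compound 3 by hydrogen in place of methyl on an oxygen on an aromatic ring. The place of the change reads the same for both pairs, so this is the same change that turns compound 1 into compound 2, now applied on the core of compound 3. Within the data shown here, the one earlier example of this change is the only guide, and it moved the number hardly at all. Compound 4 is therefore expected to give a step of about a 1.1-fold lower number from compound 3 to compound 4 (0.04 log units; within the scatter), because the same change gave a 1.1-fold lower number from compound 1 to compound 2 (0.04 log units; within the scatter). On that basis compound 4 is estimated at 6500 nM, most likely between 3000 nM and 14000 nM, though a single earlier step on a different core is a thin basis.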

Compound 4, half-maximal inhibitory concentration: 9320 nM
The estimate for compound 4 lay 1.4-fold (0.16 log units) below the measured number; measured number inside the range.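

In this assay, putting hydrogen in place of methyl on an aromatic oxygen, which here turns 4-methoxyphenyl into 4-hydroxyphenyl, gave a 1.3-fold higher number from compound 3 to compound 4 (0.11 log units; within the scatter). Set beside the one earlier example of this change, the new step cannot be told apart from it on this read-out: the same change on two cores in this assay, a 1.1-fold lower number (0.04 log units; within the scatter) from compound 1 to compound 2 and a 1.3-fold higher number (0.11 log units; within the scatter) from compound 3 to compound 4, 1.4-fold (0.15 log units) apart, within the scatter of two such steps. Across these two pairs, the change therefore produced no step beyond the scatter on either core, but two small steps do not prove that it has no effect at all, and they cannot rule out a small real shift that the scatter hides or predict what would happen on any other core.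

The compounds shown leave open whether a larger group on that same oxygen, such as an ethyl group or a longer chain, would give a step beyond the scatter. They also leave open what an amine or a carboxylic acid would do in place of the methoxy or hydroxy group, so the four compounds show only how far methoxy and hydroxy can be exchanged in this series.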